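Amide Substituent Change on a Nonsteroidal Vitamin D Receptor Agonist

The compounds below may be only part of what the source reports. "The series", "measured", "known", "first", "only" and "open" are said of these compounds alone.

Measured compounds:
- compound 1 `CCn1c(C(=O)NCCN(C)C)ccc1C(CC)(CC)c1ccc(OCC(=O)C(C)(C)C)c(C)c1`: 77 nM
- compound 2 `C#CC(C)OC(=O)c1ccc(C(CC)(CC)c2ccc(OCC(O)C(C)(C)C)c(C)c2)n1CC`: 200 nM
- compound 3 `CC[C@@H](C)[C@H](NC(=O)c1ccc(C(CC)(CC)c2ccc(OCC(O)C(C)(C)C)c(C)c2)n1CC)C(=O)O`: 2.3 nM

In an assay on HL-60 cells for agonist activity at vitamin D3 receptor (Homo sapiens), read by microscopy, with a stated time of 96 h (on this read-out lower numbers stand for an effect already at smaller amounts and higher numbers for an effect only at larger amounts of compound), compound 1 gives 77 nM, the second highest of the three numbers. Its nearest neighbour is compound 2, which gives 200 nM; the furthest is compound 3, which gives 2.3 nM. Going by the values given here, the only single-point step among the measured compounds is an 87-fold lower number from compound 2 to compound 3 (1.94 log units; beyond the scatter), where an ester is exchanged for an amide carrying a carboxylic acid.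

Compound 4 `CCOc1ccc(NC(=O)c2ccc(C(CC)(CC)c3ccc(OCC(=O)C(C)(C)C)c(C)c3)n2CC)cc1` has not yet been measured. It differs from compound 1 in one place: 4-ethoxyphenyl in place of 2-(dimethylamino)ethyl on an amide-type nitrogen. Among the compounds with values here, no measured step changes the group on the amide-type nitrogen, so the step from compound 1 to compound 4 has no direct precedent. The step of an 87-fold lower number from compound 2 to compound 3 (1.94 log units; beyond the scatter) shows only that the substituent on the carbonyl carbon of this core can move the number a great deal. With no closer guide, the expected change is a 1.3-fold higher number from compound 1 to compound 4 (0.11 log units; within the scatter), and compound 4 is estimated at 100 nM, in a range from 20 nM to 500 nM.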

Compound 4, half-maximal effective concentration: > 50000 nM
Compound 4 ended at the assay's limit; the forecaster's own chance of this, stated with the estimate: 5%; middle value at least 500-fold (2.69 log units) away from the limit.
By their numbers in this assay, from the lowest: compound 3; then compound 1; then compound 2. At a limit, above all of these: compound 4.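

On the amide-type nitrogen, 4-ethoxyphenyl in place of 2-(dimethylamino)ethyl gives an at least 640-fold higher number from compound 1 to compound 4 (2.81 log units; beyond the scatter). Compound 4 stands at a limit of this assay and not at a number: the limit of > 50000 nM in this assay, at which 1 of the 4 values shown sits. The earlier step, an 87-fold lower number from compound 2 to compound 3 (1.94 log units; beyond the scatter), exchanged an ester for an amide, whereas this step keeps the amide and changes only the group on its nitrogen, showing that this group alone can take a compound of the shared core from a measurable number to the limit.

The compounds shown leave open whether the aromatic ring, its ethoxy group or the departure of the dimethylamino group accounts for this step. A plain phenyl or a 4-(dimethylamino)phenyl on the same nitrogen would tell these apart.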